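This account rests on a few compounds, and the source may have more. Where it says the series, first, only, none or still open, it means among the compounds named here.

Compound 1 `NS(=O)(=O)c1ccc(/N=C/c2c(Cl)c3ccccc3oc2=O)cc1`: 580 nM
Compound 2 `Cc1cc(C)nc(NS(=O)(=O)c2ccc(/N=C/c3c(Cl)c4cc(C(C)(C)C)cc(C(C)(C)C)c4oc3=O)cc2)n1`: 730 nM
Compound 3 `Cc1ccnc(NS(=O)(=O)c2ccc(/N=C/c3c(Cl)c4cc(C(C)(C)C)cc(C(C)(C)C)c4oc3=O)cc2)n1`: 360 nM

These three compounds were examined in an ADME assay on cells (Macrophage, Homo sapiens) for cytotoxicity, read by microscopy and CCK-8 assay, with a stated time of 48 h; a higher number here means that more compound is tolerated, a lower number that less compound is tolerated. Compound 1 gives 580 nM there, compound 2 gives 730 nM, and compound 3 gives 360 nM. Compound 2 and compound 3 share one core and differ in a single place: methyl in place of hydrogen on an aromatic carbon. That change produced a 2.0-fold higher number from compound 3 to compound 2 (0.31 log units; beyond the scatter). Compound 1 has a different core, and the difference between the two cores is not broken down here; the value of compound 1 sits within the scatter of both compound 2 and compound 3, so no order among the three can be read.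

Compound 4 `Cc1ccc2oc(=O)c(/C=N/c3ccc(S(N)(=O)=O)cc3)c(Cl)c2c1` has not yet been measured in this assay. It is built from compound 1 by methyl in place of hydrogen on an aromatic carbon. Among the measured compounds shown here, this is the same kind of change as the one from compound 3 to compound 2, but not the same: there the methyl entered on a six-membered aromatic ring with two nitrogens, next to the ring nitrogen, meta to a large group and meta to a methyl group; here it enters a six-membered aromatic ring of carbon only, part of a fused system of two rings, meta to a fused ring and para to a fused ring.

Resting on the single measured step from compound 3 to compound 2, a step of similar, modest size is expected from compound 1 to compound 4, namely a 1.3-fold higher number from compound 1 to compound 4 (0.11 log units; within the scatter), though the different surroundings of the new methyl weaken that expectation. Compound 4 is therefore estimated to give about 750 nM in this assay, with a likely range from 350 nM to 1500 nM.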

Compound 4, minimum cytotoxic concentration: 1200 nM
Beside the measured number, compound 4's estimate is 1.6-fold (0.20 log units) below it, and the stated range covers the measured number.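

In this assay, methyl in place of hydrogen on an aromatic carbon gave a 2.1-fold higher number from compound 1 to compound 4 (0.32 log units; beyond the scatter), so more compound was tolerated after the change. Set beside the earlier step, the same change moved the number in the same direction and by a matching amount on two different cores, even though the methyl entered a different kind of ring each time: the same change on two cores in this assay, a 2.0-fold higher number (0.31 log units; beyond the scatter) from compound 3 to compound 2 and a 2.1-fold higher number (0.32 log units; beyond the scatter) from compound 1 to compound 4, 1.0-fold (0.01 log units) apart, within the scatter of two such steps This rests on only two pairs of compounds in a single assay, so it shows that the change carried over between these two cores, but not that it would do so on any other core, and it gives no reason for the rise.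

The compounds shown leave open whether this rise is particular to methyl, or whether a methoxy group, an ethyl group or a longer chain in the place it holds in compound 4 would give a step of similar size. They also leave open whether a methyl on another carbon of that ring would behave in the same way.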